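The source may hold more compounds than are shown below. What is called first, only, known or untested is meant among the compounds shown, and "the series" means these compounds.

Compound 1 `CCn1c(C(=O)Nc2cccc(C(F)(F)F)c2)ccc1C(CC)(CC)c1ccc(OCCC(O)(CC)CC)c(C)c1` is one of two compounds tested here, the other being compound 2 `CCC(C)C(NC(=O)c1ccc(C(CC)(CC)c2ccc(OCCC(O)(CC)CC)c(C)c2)n1CC)C(=O)OC`. In a functional assay on HepG2 cells (Homo sapiens) for antiproliferative activity, read by MTT assay, with a stated time of 48 h (on this read-out lower numbers stand for stronger inhibition and higher numbers for weaker inhibition), compound 1 gives > 50000 nM, which is a limit of the assay rather than a number. Compound 2 likewise gives > 50000 nM in this assay, again a limit. Within the data shown here, the one step between them, a step that the two limits leave unreadable from compound 1 to compound 2, therefore cannot be read, since (the limit of > 50000 nM in this assay, at which 2 of the 2 values shown sit).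

Compound 3 `CCn1c(C(=O)NC(C)CO)ccc1C(CC)(CC)c1ccc(OCCC(O)(CC)CC)c(C)c1` keeps the shared core of compound 1 and changes only the group on the amide-type nitrogen: 1-(hydroxymethyl)ethyl in place of 3-(trifluoromethyl)phenyl on an amide-type nitrogen.

Among the measured compounds shown here, no measured step bears directly on this change, and the only step available, from compound 1 to compound 2, has no readable size. What the data do show is that two different groups on this nitrogen both leave the compound at the limit. On that basis compound 3 is expected to stay near the same limit, so the step that the limit leaves unreadable from compound 1 to compound 3 is estimated to be none beyond the scatter. Compound 3 is therefore estimated at 80000 nM in this assay, within a range from 25000 nM to 300000 nM.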

Compound 3, half-maximal inhibitory concentration: 43100 nM
Estimate against measurement, compound 3: 1.9-fold (0.27 log units) above, and the stated range covers the measured number.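

Among the three compounds shown, compound 3 is the only one for which this assay returns a measured number rather than a limit, so the group on this amide-type nitrogen can be changed with the compound still giving a readable value. With 1-(hydroxymethyl)ethyl on this nitrogen, the step is an at least 1.1-fold lower number from compound 1 to compound 3 (0.06 log units; that floor lies within the scatter) and, against the other compound at the limit, an at least 1.1-fold lower number from compound 2 to compound 3 (0.06 log units; that floor lies within the scatter); neither floor shows a change beyond the scatter, although the true gaps may be larger. Each step is known only as a floor, not as a size, because the other two compounds sit at a limit: the limit of > 50000 nM in this assay, at which 2 of the 3 values shown sit.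

The compounds shown leave open whether the hydroxyl of the 1-(hydroxymethyl)ethyl group matters, which a plain isopropyl group in its place would test, and whether an amine, a carboxylic acid or a longer chain ending in a hydroxyl would lower the number further. They also leave open how much of the weak inhibition traces to the shared core, which is the same in all three compounds.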